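A Third Chlorobenzyl Placement in a Cell Test

The source may report more compounds than this note shows. Statements on the series, on what has been measured and on what is new or still open speak of the compounds shown alone.

In a functional assay on MDA-MB-231 cells (Homo sapiens) for cytotoxicity, read by MTT assay, with a stated time of 72 h (a higher number here means a weaker inhibitor, a lower number a stronger inhibitor), compound 1 `CN(C)Cc1ccc2nc(NC(=O)N/N=C/c3cn(Cc4ccccc4Cl)c4ccccc34)sc2c1` gives 1180 nM and compound 2 `CN(C)Cc1ccc2nc(NC(=O)N/N=C/c3cn(Cc4ccc(Cl)cc4)c4ccccc34)sc2c1` gives 880 nM. So compound 2 stands level with compound 1, as these two numbers lie within the usual scatter of each other. Compound 3 `CN(C)Cc1ccc2nc(NC(=O)N/N=C/c3cn(Cc4cccc(Cl)c4)c4ccccc34)sc2c1` differs from compound 2 by one change: 3-chlorophenyl in place of 4-chlorophenyl on a saturated chain carbon bound to an aromatic nitrogen. It carries 3-chlorophenyl in place of 4-chlorophenyl on a saturated chain carbon bound to an aromatic nitrogen, so the two have the same atoms, joined differently. Within the data shown here, only one measured step bears on this change, a similar swap of 4-chlorophenyl for 2-chlorophenyl at the same place. Because a 1.3-fold lower number from compound 1 to compound 2 (0.13 log units; within the scatter) stayed within the scatter, no step beyond the scatter is expected in this assay. The expected step is small: a 1.1-fold higher number from compound 2 to compound 3 (0.06 log units; within the scatter). For compound 3 the estimated value is 1000 nM, with an expected range from 550 nM to 1900 nM.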

Compound 3, half-maximal inhibitory concentration: 1140 nM
Beside the measured number, compound 3's estimate is 1.1-fold (0.06 log units) below it; the measured number falls inside the stated range.
By their numbers in this assay, from the lowest: compounds 2, 3 and 1 (each within the scatter of the next).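

In this assay, 3-chlorophenyl in place of 4-chlorophenyl on a saturated chain carbon bound to an aromatic nitrogen gives a 1.3-fold higher number from compound 2 to compound 3 (0.11 log units; within the scatter) and stays level, and 3-chlorophenyl in place of 2-chlorophenyl gives a 1.0-fold lower number from compound 1 to compound 3 (0.01 log units; within the scatter) and does the same. With all three chlorophenyl forms now in hand, none stands apart from the others, so moving the chlorine around this ring does not separate these compounds in this cell test. No measurement shown here offers an explanation for this flat result.

The compounds shown leave open whether the chlorine matters at all, since every one of them carries it. A methoxy group or a carboxylic acid on this ring, or a longer chain joining the ring to the aromatic nitrogen, could still give a clearly different number.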